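Swapping sec-butyl for butyl in compound 1

A few compounds are considered here, and "the series" means these few. Any claim that something is new, unique, unknown or untested is made for them only; others in the source may bear on it.

In an ADME assay on the whole organism for inhibition, with Oryza sativa as the target, with a stated time of 4 days (on this read-out higher numbers stand for weaker inhibition and lower numbers for stronger inhibition), compound 1 (`CC[C@H](C)Nc1nc(Cl)nc(N[C@@H](C)c2ccccc2)n1`) gives 6920 nM and compound 2 (`CC[C@@H](C)Nc1nc(Cl)nc(N[C@H](C)c2ccccc2)n1`) gives 8320 nM within the scatter of each other, while compound 3 (`CCCN(CC)c1nc(Cl)nc(N[C@H](C)c2ccccc2)n1`) reads higher at 24500 nM on the same scale. Compound 4 (`CCCCNc1nc(Cl)nc(N[C@@H](C)c2ccccc2)n1`) is still unmeasured and differs from compound 1 in one place (butyl in place of sec-butyl on a nitrogen on an aromatic ring) with butyl in place of sec-butyl on a nitrogen on an aromatic ring. Going by the values given here, two measured steps bear on this. The mirror-image swap gave a 1.2-fold higher number from compound 1 to compound 2 (0.08 log units; within the scatter) and so changed little, whereas ethyl(propyl)amino in place of (sec-butyl)amino gave a 2.9-fold higher number from compound 2 to compound 3 (0.47 log units; beyond the scatter) as a modest change. A slightly higher number is therefore expected, with a 1.4-fold higher number from compound 1 to compound 4 (0.14 log units; within the scatter) as the estimated step in this assay at about the size of the scatter. Compound 4 is estimated at 9500 nM within an expected range from 4500 nM to 20000 nM on this read-out.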

Compound 4, half-maximal inhibitory concentration: 23400 nM
Compound 4: the middle estimate sits 2.5-fold (0.39 log units) below what was measured, and the stated range ends below it.
By their numbers in this assay, from the lowest: compounds 1 and 2 (each within the scatter of the next); then compounds 4 and 3 (each within the scatter of the next).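

With the same four carbons on a nitrogen on an aromatic ring, butyl in place of sec-butyl gives a 3.4-fold higher number from compound 1 to compound 4 (0.53 log units; beyond the scatter) in this assay, so this position responds to how the chain is arranged and not only to its atom count. The earlier step, a 1.2-fold higher number from compound 1 to compound 2 (0.08 log units; within the scatter), could not show this, because the branch stays in place there and that step rests on a single difference: the fact that compounds 1 and 2 differ only in the configuration as drawn

From the compounds shown here alone, whether isobutyl or cyclobutyl at this position would read like compound 1 or like compound 4 remains open. Going by these compounds, both stereocentres invert together in compound 2, so the effect of either one alone also remains open.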